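The compounds below may be only part of what the source reports. "The series", "measured", "known", "first", "only" and "open" are said of these compounds alone.

Compound 1 `CC(=O)N1CCc2nc(C#Cc3ccccc3)sc2C1`: > 10000 nM
Compound 2 `O=C(CC1CCOCC1)N1CCc2nc(C#Cc3ccccc3)sc2C1`: 470 nM

Of the compounds shown here, two sharing one core have so far been measured in an assay on HEK293 cells for positive allosteric modulation of metabotropic glutamate receptor 5 (Homo sapiens), read by FLIPR, with a stated time of 1 h; on this read-out higher numbers stand for an effect only at larger amounts of compound and lower numbers for an effect already at smaller amounts. For compound 1 the result is only a limit of the assay, > 10000 nM, so no number stands for it (the limit of > 10000 nM in this assay, at which 1 of the 2 values shown sits). Compound 2 gives 470 nM in this assay, and this is the only number shown. Within the data shown here, the single measured step, an at least 21-fold lower number from compound 1 to compound 2 (1.32 log units; beyond the scatter), puts oxan-4-yl in place of hydrogen on a saturated chain carbon bound to a carbonyl carbon.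

Compound 3 `O=C(c1cccc(Cl)c1)N1CCc2nc(C#Cc3ccccc3)sc2C1` has not been measured. It differs from compound 2 in one place: 3-chlorophenyl in place of (oxan-4-yl)methyl on a carbonyl carbon. The change sits on the same carbonyl carbon that was altered in the measured step, where a group entering in place of hydrogen went with a large gain. The groups that leave and enter here are matched in heavy-atom count, as the tally shows, so compound 3 is expected to stay close to compound 2, with a step of a 1.3-fold lower number from compound 2 to compound 3 (0.13 log units; within the scatter) that lies within the scatter. In this assay compound 3 is estimated at 350 nM, with a range from 100 nM to 1500 nM.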

Compound 3, half-maximal effective concentration: 8.7 nM
Compound 3: middle estimate off by 40-fold (1.60 log units), on the high side, outside the stated range (below it).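

In this assay, the step of a 54-fold lower number from compound 2 to compound 3 (1.73 log units; beyond the scatter) shows that matching the heavy-atom count of the leaving and entering groups does not keep the number in place on this carbonyl carbon, whose other neighbour is the amide-type nitrogen in a ring. The earlier step could be read as a gain that came with a larger group in place of hydrogen, whereas here the identity of the group changes the result at equal count, with 3-chlorophenyl well ahead of (oxan-4-yl)methyl. Against the methyl group, 3-chlorophenyl gives an at least 1100-fold lower number from compound 1 to compound 3 (3.06 log units; beyond the scatter), and this step has only a lower bound, as compound 1 is represented by a limit and not a number: the limit of > 10000 nM in this assay, at which 1 of the 3 values shown sits.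

The exchange alters several things together, since an aromatic carbon ring replaces a non-aromatic ring with a hetero atom, chlorine enters and the ring oxygen leaves, so the compounds shown do not separate the contribution of each. On these data alone, how a plain phenyl, a 4-chlorophenyl or a pyridine ring on the same carbonyl carbon would read remains open.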